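This account rests on a few compounds, and the source may have more. Where it says the series, first, only, none or still open, it means among the compounds named here.

Measured so far:
compound 1, `Cc1cc(O)cc(-c2nn(CC#N)cc2-c2ccnc(-c3ccc(Oc4ccccc4)cc3)c2)c1`: 88%
compound 2, `COc1cc(C)cc(-c2nn(CC#N)cc2-c2ccnc(-c3ccc(N(C)C)cc3)c2)c1`: 91%

In a functional assay on A498 cells (Homo sapiens) for cytotoxicity, read by sulforhodamine B assay, with a stated time of 48 h, tested at 0.001 uM (a higher number here means a weaker effect of the compound at the concentration tested, a lower number a stronger effect), compound 2 gives 91%, the higher of the two numbers. Compound 1 gives 88%, lower by an amount within the scatter, so nothing separates the two.

Compound 3, `Cc1cc(O)cc(-c2nn(CC#N)cc2-c2ccnc(-c3ccc(N(C)C)cc3)c2)c1`, is not yet measured in this assay. It differs from compound 2 in one place: hydrogen in place of methyl on an oxygen on an aromatic ring. Among the compounds with values here, no step between measured compounds is known for this change, so its size here is untested. Compound 1, which already carries the hydroxy, gives 88%, and compound 2, with the methoxy, gives 91%; the two numbers lie within the scatter of each other, so no step beyond the scatter is expected in this assay, in either direction. Compound 3 is therefore expected to give 89%, within 80% to 97%. The expected step is a number 2 percentage points lower from compound 2 to compound 3 (within the scatter), essentially none beyond the scatter.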

Compound 3, a percentage reported as activity, at one concentration (the size of the read-out at that concentration, not a potency): 101%
Estimate against measurement, compound 3: 12 percentage points below; measured number outside the range, above it.
By their numbers in this assay, from the lowest: compounds 1, 2 and 3 (each within the scatter of the next, the first and the last beyond it).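

In this assay, the change from methoxy to hydroxy on the 3-methoxy-5-methylphenyl group gives a number 10 percentage points higher from compound 2 to compound 3 (within the scatter) and does not separate hydrogen from methyl on this oxygen. With the hydroxy held constant, dimethylamino in place of phenoxy on an aromatic carbon gives a number 13 percentage points higher from compound 1 to compound 3 (beyond the scatter) and is the only step shown that lies beyond the scatter, so at this single concentration the phenoxy-bearing compound 1 keeps a modest edge over compound 3. Nothing shown gives a reason for either step.

Going by these compounds, whether a longer chain on this oxygen, such as ethoxy, or an amine in place of the hydroxy would shift the reading remains open. On these data alone, the size of the effect at other concentrations also remains open, since one low concentration cannot show how these compounds compare at higher concentrations.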